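Shortening the acid chain: what compound 4 should give

The source may hold more compounds than are shown below. What is called first, only, known or untested is meant among the compounds shown, and "the series" means these compounds.

Compound 3 `O=C(O)CCc1ccc(S(=O)(=O)NNc2ccc(Br)cc2)cc1` gives 183 nM in an assay on HeLa cells for inhibition of Indoleamine 2,3-dioxygenase 1 (Homo sapiens), read by spectrophotometry, with a stated time of 24 h; a lower number here means that less compound is needed, a higher number that more compound is needed for the effect. Compound 1 `O=S(=O)(NNc1ccc(Br)cc1)c1ccccc1` gives 128 nM and compound 2 `O=S(=O)(NNc1ccc(Br)cc1)c1ccc(Br)cc1` gives 374 nM in this assay, so compound 3 holds the second highest of the three numbers, within the scatter of compound 1 while a 2.0-fold lower number from compound 2 to compound 3 (0.31 log units; beyond the scatter) lies beyond it. Compound 4 `O=C(O)c1ccc(S(=O)(=O)NNc2ccc(Br)cc2)cc1` differs from compound 3 by carboxy in place of 2-carboxyethyl on an aromatic carbon. Within the data shown here, no measured step removes part of this chain; the nearest guides are a 1.4-fold higher number from compound 1 to compound 3 (0.16 log units; within the scatter), which stays within the scatter, and the modest 2.0-fold lower number from compound 2 to compound 3 (0.31 log units; beyond the scatter). On that basis, no step beyond the scatter is expected, and a 1.1-fold higher number from compound 3 to compound 4 (0.04 log units; within the scatter) is the estimated change. Compound 4 is therefore expected at about 200 nM, in a range from 80 nM to 500 nM.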

Compound 4, half-maximal effective concentration: 172 nM
Estimate against measurement, compound 4: 1.2-fold (0.07 log units) above; the measured number falls inside the stated range.
By their numbers in this assay, from the lowest: compounds 1, 4 and 3 (each within the scatter of the next); then compound 2.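

Shortening 2-carboxyethyl to carboxy leaves the number in this assay within the scatter (a 1.1-fold lower number from compound 3 to compound 4 (0.03 log units; within the scatter)), so these two acid chain lengths cannot be told apart at this position. Carboxy also stays within the scatter of plain hydrogen (a 1.3-fold higher number from compound 1 to compound 4 (0.13 log units; within the scatter)), whereas bromo remains the one group here that stands apart, now from carboxy as well (a 2.2-fold lower number from compound 2 to compound 4 (0.34 log units; beyond the scatter)). No measurement shown here explains this pattern.

From the compounds shown here alone, whether a longer acid chain, a methyl ester of the acid or an amine at this position would also stay within the scatter remains open.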